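A few compounds are considered here, and "the series" means these few. Any claim that something is new, unique, unknown or untested is made for them only; others in the source may bear on it.

Measured compounds in this series:
- compound 1 `COc1ccccc1-n1nncc1CN1C(=O)C2(C(C#N)=C(N)Oc3c(N)cc4nc5ccccc5nc4c32)c2ccccc21` — 37500 nM
- compound 2 `N#CC1=C(N)Oc2c(N)cc3nc4ccccc4nc3c2C12C(=O)N(Cc1cnnn1-c1c(F)cccc1F)c1ccccc12` — > 50000 nM, a limit of the assay

In a functional assay on A549 cells (Homo sapiens) for antiproliferative activity, read by MTT assay, with a stated time of 48 h (on this read-out lower numbers stand for stronger inhibition and higher numbers for weaker inhibition), compound 1 gives 37500 nM. For compound 2 this assay reports only a limit, > 50000 nM, so compound 2 stands at the limit of > 50000 nM in this assay, at which 1 of the 2 values shown sits, and carries no number of its own. Among the measured compounds shown here, the single measured step, an at least 1.3-fold higher number from compound 1 to compound 2 (0.12 log units; that floor lies within the scatter), is the only change recorded on the aromatic nitrogen, and its floor lies within the scatter.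

Compound 3 `COc1cc(-n2nncc2CN2C(=O)C3(C(C#N)=C(N)Oc4c(N)cc5nc6ccccc6nc5c43)c3ccccc32)c(OC)cc1Cl` differs from compound 2 in one place: 4-chloro-2,5-dimethoxyphenyl in place of 2,6-difluorophenyl on an aromatic nitrogen. For the measured compounds named here, no measured step covers this change, and the one step on the same aromatic nitrogen gives no direction beyond the scatter. Compound 3 is therefore expected to sit close to compound 2, most likely again at the limit of this assay, with an estimated 50000 nM and a range from 25000 nM to 100000 nM. The implied step a number no higher from compound 2 to compound 3 (the limit leaves the size open) is expected to stay within the scatter.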

Compound 3, half-maximal inhibitory concentration: > 50000 nM
Compound 3 was reported as a limit; the forecaster's own chance of this, stated with the estimate: 55%; the middle value sits exactly at the limit.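

Compound 3 is the second compound at a limit of this assay: the limit of > 50000 nM in this assay, at which 2 of the 3 values shown sit. With 4-chloro-2,5-dimethoxyphenyl in place of 2-methoxyphenyl on the aromatic nitrogen, the change gives an at least 1.3-fold higher number from compound 1 to compound 3 (0.12 log units; that floor lies within the scatter), so no direction can be read from it. The step between the two limits cannot be read, and both the 2,6-difluorophenyl and the 4-chloro-2,5-dimethoxyphenyl compounds report no number of their own.

Open, from the compounds shown here alone, is whether another group on this nitrogen, such as a benzyl or a phenyl carrying an amine or a carboxylic acid, gives a value clearly apart from the limit. Going by these compounds, how far compound 2 and compound 3 lie beyond the limit also stays unknown.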